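From 4-bromobenzyl to 4-nitrobenzyl in the toxicity read-out

This account rests on a few compounds, and the source may have more. Where it says the series, first, only, none or still open, it means among the compounds named here.

Compound 1 `Cc1cc(N2CC[C@@H](C)[C@@H](N(C)c3ncnc4[nH]ccc34)C2)n2nc(SCc3ccc(F)c(Cl)c3)nc2n1` reads > 100000 nM in a toxicity assay on GES1 cells (Homo sapiens) for inhibition, read by MTT assay, with a stated time of 72 h (on this read-out higher numbers stand for weaker inhibition and lower numbers for stronger inhibition), which is a limit of the assay and not a number. Going by the values given here, compound 2 `Cc1cc(N2CC[C@@H](C)[C@@H](N(C)c3ncnc4[nH]ccc34)C2)n2nc(SCc3ccc(Br)cc3)nc2n1` gives 55600 nM in this assay, the only true number so far, so its standing rests on this single value. Among the compounds with values here, the one measured step, an at least 1.7-fold lower number from compound 1 to compound 2 (0.25 log units; that floor lies within the scatter), exchanges one aryl group for another on a saturated chain carbon bound to a sulfur, and its floor lies within the scatter.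

Compound 3 `Cc1cc(N2CC[C@@H](C)[C@@H](N(C)c3ncnc4[nH]ccc34)C2)n2nc(SCc3ccc([N+](=O)[O-])cc3)nc2n1` changes that same aryl group again: nitro in place of bromo on an aromatic carbon, para to a large group. Given an at least 1.7-fold lower number from compound 1 to compound 2 (0.25 log units; that floor lies within the scatter) as the only guide, no change beyond the scatter is expected in this assay, and no direction is favoured. The expected step is a 1.1-fold higher number from compound 2 to compound 3 (0.03 log units; within the scatter). For compound 3 the estimate is 60000 nM, with an expected range of 25000 nM to 100000 nM. The upper end of that range reaches the ceiling seen so far: the limit of > 100000 nM in this assay, at which 1 of the 2 values shown sits.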

Compound 3, half-maximal inhibitory concentration: 36600 nM
Compound 3: the middle estimate sits 1.6-fold (0.21 log units) above what was measured; the measured number falls inside the stated range.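

In this assay, nitro in place of bromo on an aromatic carbon, para to a large group, gives a 1.5-fold lower number from compound 2 to compound 3 (0.18 log units; within the scatter). This exchange adds heavy atoms and two hydrogen-bond acceptors at this position, yet it does not separate compound 3 from compound 2 in this read-out. Across the aryl change on the saturated chain carbon bound to a sulfur, the series now has its first step beyond the scatter, an at least 2.7-fold lower number from compound 1 to compound 3 (0.43 log units; beyond the scatter), although compound 1 stands at a limit of the assay and not a number, so this step gives only a floor: the limit of > 100000 nM in this assay, at which 1 of the 3 values shown sits.

Going by these compounds, whether an amine or a carboxylic acid on the same aromatic carbon would separate from compound 3 beyond the scatter remains open, as does the effect of a longer chain in place of the benzyl group. On these data alone, the true size of the gap from compound 1 to compound 3 also remains open, and the shared core is the same in all three compounds, so these values say nothing about changes there.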